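Notes on replacing the carboxybenzyl arm of compound 3

The source may hold more compounds than are shown below. What is called first, only, known or untested is meant among the compounds shown, and "the series" means these compounds.

Measured so far in an assay on cells for agonist activity at Bombesin receptor subtype-3 (Homo sapiens), read by HTRF and inositol phosphate accumulation, with a stated time of 1 h; on this read-out lower numbers stand for an effect already at smaller amounts and higher numbers for an effect only at larger amounts of compound:
- compound 1 `COC(=O)c1ccccc1-c1ccc(CCc2ncc(CC(C)(C)C)n2CC(=O)O)cc1`: 968 nM
- compound 2 `COC(=O)c1c(F)cccc1-c1ccc(CCc2ncc(CC(C)(C)C)n2Cc2ccc(C(=O)O)cc2)cc1`: 3 nM
- compound 3 `CC(C)(C)Cc1cnc(CCc2ccc(-c3cccc(F)c3C(=O)O)cc2)n1Cc1ccc(C(=O)O)cc1`: 12 nM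

Compound 3 holds the second highest of the three numbers. Within the data shown here, its nearest neighbour is compound 2, the only step measured in one place, a 4.0-fold higher number from compound 2 to compound 3 (0.60 log units; beyond the scatter); compound 1 lies furthest away, with a far higher number.

Compound 4 `CC(C)(C)Cc1cnc(CCc2ccc(-c3cccc(F)c3C(=O)O)cc2)n1CCNS(C)(=O)=O` differs from compound 3 as follows: (methanesulfonamido)methyl in place of 4-carboxyphenyl on a saturated chain carbon bound to an aromatic nitrogen. Among the measured compounds shown here, no measured step touches this position alone. The step from compound 2 to compound 3 concerns the ester and not the group on the nitrogen, so it does not bear on this change. Compound 1 and compound 2 differ in two places, so only their two values can be compared: compound 1, carrying a short acid chain on that nitrogen, gives a number far above compound 2, which carries the 4-carboxybenzyl. This suggests that the group on that nitrogen weighs heavily, though the fluorine also changes between them.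

On that basis a clear loss is expected for compound 4, estimated as a 13-fold higher number from compound 3 to compound 4 (1.10 log units; beyond the scatter), giving an expected 150 nM with a range from 30 nM to 800 nM in this assay.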

Compound 4, half-maximal effective concentration: 2 nM
Estimate against measurement, compound 4: 75-fold (1.88 log units) above; measured number below the stated range.
By their numbers in this assay, from the lowest: compounds 4 and 2 (each within the scatter of the next); then compound 3; then compound 1.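

In this assay, among these compounds, (methanesulfonamido)methyl in place of 4-carboxyphenyl on a saturated chain carbon bound to an aromatic nitrogen gives a 6.0-fold lower number from compound 3 to compound 4 (0.78 log units; beyond the scatter), the first reading of this position with the rest of the molecule held fixed. With the shared core and its free acid kept as in compound 3, a low number therefore needs neither the aromatic ring nor the carboxylic acid of the 4-carboxybenzyl arm, and 2-(methanesulfonamido)ethyl, a smaller arm without a ring, serves at least as well. Nothing in the data at hand explains this step.

Still open, as far as these compounds go, is whether the methanesulfonamide is itself needed here, or whether an amide, an amine or a longer chain ending in the same group on this carbon would read the same in this assay. Also open, from the compounds shown here alone, is whether the change from methyl ester to acid (a 4.0-fold higher number from compound 2 to compound 3 (0.60 log units; beyond the scatter)) would carry over to compounds with the 2-(methanesulfonamido)ethyl arm, as that step has been read only with the 4-carboxybenzyl arm.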